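A few compounds are considered here, and "the series" means these few. Any claim that something is new, unique, unknown or untested is made for them only; others in the source may bear on it.

In a functional assay on HepG2 cells (Homo sapiens) for antiproliferative activity, read by MTT assay, with a stated time of 72 h (a lower number here means a stronger inhibitor, a higher number a weaker inhibitor), compound 1 `COc1ccc(Cn2c(C(=O)O)c(CNCc3cccc(O)c3)c3ccc(C(C)C)cc32)cc1` gives 4920 nM, the lowest of the three numbers in hand. Compound 3 `COc1cccc(CNCc2c(C(=O)O)n(Cc3ccccc3)c3cc(C)ccc23)c1` gives 5210 nM, within the scatter of compound 1. Compound 2 `COc1cccc(CNCc2c(C(=O)O)n(Cc3ccc(C)cc3)c3ccccc23)c1` gives 14000 nM, a higher number beyond the scatter of compound 1, so compound 2 is the weaker inhibitor of that pair. Compound 4 `COc1ccc(Cn2c(C(=O)O)c(CNCc3cccc(O)c3)c3ccc(C)cc32)cc1` is the next case; it differs from compound 1 by methyl in place of isopropyl on an aromatic carbon. Within the data shown here, no measured pair shows this change on its own, so the data give no direct guide to the size of the step. A small step, probably within the scatter with a lean toward a higher number, is expected: a 1.3-fold higher number from compound 1 to compound 4 (0.12 log units; within the scatter). Compound 4 is accordingly expected to give 6500 nM, in the range 3000 nM to 14000 nM.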

Compound 4, half-maximal inhibitory concentration: 4520 nM
Beside the measured number, compound 4's estimate is 1.4-fold (0.16 log units) above it, within the range that was stated.
By their numbers in this assay, from the lowest: compounds 4, 1 and 3 (each within the scatter of the next); then compound 2.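

In this assay, among these compounds, this is the first pair of the series that differs in one place, and it gives a 1.1-fold lower number from compound 1 to compound 4 (0.04 log units; within the scatter). On this aromatic carbon of the shared core, methyl and isopropyl therefore cannot be told apart. No measured property available here accounts for this result.

As far as these compounds go, whether an amine, a fluorine atom or a longer chain at this carbon would move the number beyond the scatter remains open. From the compounds shown here alone, it is also open whether the same change would give a similar step with other groups elsewhere on the core.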